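Changing the aryl group of compound 2

A few compounds are considered here, and "the series" means these few. Any claim that something is new, unique, unknown or untested is made for them only; others in the source may bear on it.

Measured so far in a functional assay on DU-145 cells (Homo sapiens) for inhibition, read by trypan blue exclusion, with a stated time of 96 h; a lower number here means a stronger inhibitor of growth, a higher number a weaker inhibitor of growth:
compound 1 `CN(C)c1ccc(/C=C(/SCc2ccc(Cl)cc2)C(=O)c2ccc(C(=O)O)cc2)cc1` gives 1000 nM
compound 2 `O=C(O)c1ccc(C(=O)/C(=C\c2ccc(Br)c([N+](=O)[O-])c2)SCc2ccc(Cl)cc2)cc1` gives < 1000 nM (a limit, not a number)
compound 3 `O=C(O)c1ccc(C(=O)/C(=C\c2ccc(Br)c([N+](=O)[O-])c2)SCc2ccc(Cl)cc2Cl)cc1` gives 1000 nM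

Compound 2 has no exact number, since < 1000 nM is only a limit of this assay and marks where it stands.

The next compound is compound 4 `COc1ccc(/C=C(/SCc2ccc(Cl)cc2)C(=O)c2ccc(C(=O)O)cc2)cc1`, which keeps the rest of compound 2 and changes one group: 4-methoxyphenyl in place of 4-bromo-3-nitrophenyl on a double-bonded chain carbon bound to a double-bonded chain carbon (4-methoxyphenyl in place of 4-bromo-3-nitrophenyl).

Two measured steps give some guidance. The closer one, a number no higher from compound 1 to compound 2 (the limit leaves the size open), changes the same place, but its size cannot be read. On these data alone, the other, a number no lower from compound 2 to compound 3 (the limit leaves the size open), changes a different place, and its size is also open. The firmest reference is therefore compound 1 at 1000 nM, which also has a single named group on that ring in place of the 4-bromo-3-nitrophenyl.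

The expected change is small and, if anything, toward a higher number: the estimated a number no lower from compound 2 to compound 4 (the limit leaves the size open) is no more than a rough guide. For compound 4 the estimate is 1000 nM, with an expected range from 300 nM to 3500 nM.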

Compound 4, concentration for 50% growth inhibition: 10000 nM
For compound 4 the middle estimate is 10-fold (1.00 log units) below the measured one; measured number above the stated range.
By their numbers in this assay, from the lowest: compounds 1 and 3 (each within the scatter of the next); then compound 4.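

Replacing 4-bromo-3-nitrophenyl with 4-methoxyphenyl on a double-bonded chain carbon bound to a double-bonded chain carbon gives, in this assay, an at least 10-fold higher number from compound 2 to compound 4 (1.00 log units; beyond the scatter). The result for compound 2 is a limit, not a number: the limit of < 1000 nM in this assay, at which 1 of the 4 values shown sits.

Among the compounds shown here, a smaller swap on the same ring, methoxy in place of dimethylamino, gives a 10-fold higher number from compound 1 to compound 4 (1.00 log units; beyond the scatter), so a single group on this ring can move the number beyond the scatter, a size that the earlier steps, which cannot be read, did not show.

The compounds shown do not separate the bromo from the nitro of compound 2, since neither group appears alone on the ring. On these data alone, how an unsubstituted phenyl or a hydroxy group would read at this place also remains open.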